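The source may report more compounds than this note shows. Statements on the series, on what has been measured and on what is new or still open speak of the compounds shown alone.

Working notes on the series built on the core of compound 1. In a functional assay on MCF7 cells (Homo sapiens) for inhibition, read by MTT assay, with a stated time of 48 h (a higher number here means a weaker inhibitor, a lower number a stronger inhibitor), compound 1 `O=C1N/C(=N\Cc2ccccc2)S/C1=C1/CCNC(=O)c2[nH]ccc21` gives 31100 nM and compound 3 `O=C1N/C(=N\Cc2cccc(Cl)c2)S/C1=C1/CCNC(=O)c2[nH]ccc21` gives 20700 nM. Among the compounds with values here, these are the only two numbers so far, and they lie within the scatter of each other. Compound 2 `O=C1N/C(=N\Cc2ccc(C(F)(F)F)cc2)S/C1=C1/CCNC(=O)c2[nH]ccc21` reads > 100000 nM, which is a limit of the assay and not a number.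

Compound 4 `O=C1N/C(=N\Cc2ccc(F)cc2)S/C1=C1/CCNC(=O)c2[nH]ccc21` is next, with the change from compound 3 being 4-fluorophenyl in place of 3-chlorophenyl on a saturated chain carbon bound to a double-bonded nitrogen. Within the data shown here, two measured steps bear on this. Chloro in place of hydrogen gave a 1.5-fold lower number from compound 1 to compound 3 (0.18 log units; within the scatter), and trifluoromethyl in place of hydrogen gave an at least 3.2-fold higher number from compound 1 to compound 2 (0.50 log units; beyond the scatter). Fluoro has no measured step of its own, so the expectation stays close to compound 3 at 20700 nM, with more room upward given the size of an at least 3.2-fold higher number from compound 1 to compound 2 (0.50 log units; beyond the scatter).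

The expected change is small, a 1.4-fold higher number from compound 3 to compound 4 (0.13 log units; within the scatter), and not clearly beyond the scatter in this assay. For compound 4 the estimated value is 28000 nM, with an expected range of 11000 nM to 80000 nM.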

Compound 4, half-maximal inhibitory concentration: 43100 nM
Estimate against measurement, compound 4: 1.5-fold (0.19 log units) below, within the range that was stated.
By their numbers in this assay, from the lowest: compounds 3, 1 and 4 (each within the scatter of the next, the first and the last beyond it). At a limit, above all of these: compound 2.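

In this assay, within the data shown here, 4-fluorophenyl in place of 3-chlorophenyl gives a 2.1-fold higher number from compound 3 to compound 4 (0.32 log units; beyond the scatter), the first step beyond the scatter at this position with a number at both ends. Fluoro in place of hydrogen gives a 1.4-fold higher number from compound 1 to compound 4 (0.14 log units; within the scatter), so this halogen alone shows no separable change from the unsubstituted benzyl group, whereas the step from 3-chlorophenyl changes both the halogen and where it sits. The reading for compound 2 is a limit and not a number, so an at least 2.3-fold lower number from compound 2 to compound 4 (0.36 log units; beyond the scatter) is a bound only: the limit of > 100000 nM in this assay, at which 1 of the 4 values shown sits.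

On these data alone, what 3-fluorophenyl or 4-chlorophenyl would give here stays open, and with it whether the step follows the halogen or its place. Also open, as far as these compounds go, is how an amine or a carboxylic acid on the same ring would read.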